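Propyl to Butyl: One Carbon More on Compound 1

The source may hold more compounds than are shown below. What is called first, only, known or untested is meant among the compounds shown, and "the series" means these compounds.

Compound 1, `CCCOC1=C(CCC)C(=O)/C(=C(O)/C=C/c2ccccc2)C(=O)C1(CCC)CCC`: 8.6 uM
Compound 2, `COC1=C(CCC(C)C)C(=O)/C(=C(O)/C=C/c2ccccc2)C(=O)C1(CCC(C)C)CCC(C)C`: "not active" (no number reported)

Among the measured compounds shown here, in a functional assay on PC-3 cells (Homo sapiens) for antiproliferative activity, read by sulforhodamine B assay, with a stated time of 3 days (on this read-out higher numbers stand for an effect only at larger amounts of compound and lower numbers for an effect already at smaller amounts), compound 1 gives 8.6 uM, the only number in hand. Compound 2 is reported in this assay as "not active" (no number reported) with no number. Compound 3, `CCCCOC1=C(CCC)C(=O)/C(=C(O)/C=C/c2ccccc2)C(=O)C1(CCC)CCC`, differs from compound 1 by methyl in place of hydrogen on a saturated chain carbon, three bonds along the chain from an oxygen on an unsaturated carbon, turning propyl into butyl. For the measured compounds named here, no measured pair shows what such a change does here, so the step in this assay is expected to be small, in no clear direction, and within the usual scatter. Compound 3 is therefore expected to give 8 uM, likely between 3 uM and 25 uM. The estimated step of a 1.1-fold lower number from compound 1 to compound 3 (0.03 log units; within the scatter) amounts to no real change.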

Compound 3, concentration for half-maximal effect: 9.6 uM
The estimate for compound 3 lay 1.2-fold (0.08 log units) below the measured number, and the stated range covers the measured number.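

Turning propyl into butyl, with methyl in place of hydrogen on a saturated chain carbon, three bonds along the chain from an oxygen on an unsaturated carbon, gives in this assay a 1.1-fold higher number from compound 1 to compound 3 (0.05 log units; within the scatter). Among the compounds shown here, this is the first measured sign that this position accepts one more carbon with no real change in the read-out. Nothing available explains this result. As far as these compounds go, whether a longer chain such as hexyl, or a chain carrying an amine, would keep this level of effect remains open.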